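The source may hold more compounds than are shown below. What is called first, only, known or untested is meant among the compounds shown, and "the series" means these compounds.

Within the data shown here, only two compounds sharing one core have numbers so far in a functional assay on HeLa cells (Homo sapiens) for antiproliferative activity, read by MTT assay, with a stated time of 48 h (on this read-out lower numbers stand for stronger inhibition and higher numbers for weaker inhibition), for now. There compound 1 (`COc1ccc(C(=O)c2cc(OC)c(OC)c(OC)c2)c(NC(=O)CO)c1`) gives 70 nM with a hydroxy group on a saturated chain carbon bound to a carbonyl carbon. Compound 2 (`CNCC(=O)Nc1cc(OC)ccc1C(=O)c1cc(OC)c(OC)c(OC)c1`), with methylamino in that place, gives 690 nM and so holds the higher of the two numbers. Compound 3 (`CCNCC(=O)Nc1cc(OC)ccc1C(=O)c1cc(OC)c(OC)c(OC)c1`) departs from compound 2 in one place: methyl in place of hydrogen on a saturated chain carbon bound to an amine nitrogen, which is methyl in place of hydrogen on a saturated chain carbon bound to an amine nitrogen, so that methylamino becomes ethylamino. Among the measured compounds shown here, the one measured step, a 9.9-fold higher number from compound 1 to compound 2 (0.99 log units; beyond the scatter), lies beyond the scatter, but it exchanges hydroxy for methylamino and bears only loosely on this smaller edit. For the measured compounds named here, no measured step alters the group on the amine nitrogen. In this assay no step beyond the scatter is therefore expected, with compound 2 at 690 nM as the anchor, and the estimated change is a 1.1-fold higher number from compound 2 to compound 3 (0.04 log units; within the scatter) in size. For compound 3 the estimate is 750 nM, with an expected range from 280 nM to 2000 nM in this read-out.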

Compound 3, half-maximal inhibitory concentration: 2100 nM
Estimate against measurement, compound 3: 2.8-fold (0.45 log units) below; the whole stated range lies below it.
By their numbers in this assay, from the lowest: compound 1; then compound 2; then compound 3.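

In this assay, the methyl that turns methylamino into ethylamino, placed on a saturated chain carbon bound to an amine nitrogen, gives a 3.0-fold higher number from compound 2 to compound 3 (0.48 log units; beyond the scatter), so this site responds to the addition of a single carbon, which the earlier exchange of hydroxy for methylamino could not show. Exchanging hydroxy for ethylamino on a saturated chain carbon bound to a carbonyl carbon gives a 30-fold higher number from compound 1 to compound 3 (1.48 log units; beyond the scatter), and across these three compounds, with none going against it, the number rises from hydroxy through methylamino to ethylamino. No evidence is at hand that bears on what lies behind this rise.

The compounds shown leave open whether the number keeps rising with a longer chain on the amine nitrogen, such as propylamino, or with a branched group such as isopropylamino. They also leave open where a plain amino group or a dimethylamino group would fall relative to hydroxy and the two secondary amines, and whether the same order would hold outside this assay.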